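The compounds below may be only part of what the source reports. "The series", "measured", "known", "first", "only" and "open" are said of these compounds alone.

In a functional assay on RS4-11 cells (Homo sapiens) for inhibition, read by CCK-8 assay, with a stated time of 48 h, tested at 20 uM (on this read-out lower numbers stand for less inhibition of growth and higher numbers for more inhibition of growth at the one concentration tested), compound 1 (`COc1ccc(S(=O)(=O)Oc2ccccc2/C=C(\C#N)C(=O)Nc2nnc(-c3cccs3)s2)cc1`) gives 76%, compound 2 (`N#C/C(=C\c1ccccc1OS(=O)(=O)c1ccc([N+](=O)[O-])cc1)C(=O)Nc1nnc(-c2cccs2)s1`) gives 40% and compound 3 (`COc1ccccc1-c1nnc(NC(=O)/C(C#N)=C/c2cccc(OS(=O)(=O)c3ccc(C)cc3)c2)s1`) gives 41%. Compound 2 thus stands level with compound 3, within the scatter, and well under compound 1. Compound 4 (`N#C/C(=C\c1ccccc1OS(=O)(=O)c1ccc([N+](=O)[O-])cc1)C(=O)Nc1nnc(Cc2ccc(Cl)cc2)s1`) differs from compound 2 in one group, 4-chlorobenzyl in place of thiophen-2-yl on an aromatic carbon. Among the measured compounds shown here, the only measured step, a number 36 percentage points lower from compound 1 to compound 2 (beyond the scatter), is large, but it swaps methoxy for nitro elsewhere in the molecule and does not touch this group. For the measured compounds named here, no measured step changes thiophen-2-yl, so no shift beyond the scatter is expected, though with wide uncertainty. The expected size is a number 5 percentage points higher from compound 2 to compound 4 (within the scatter). In this assay the estimate for compound 4 is 45%, expected between 25% and 65%.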

Compound 4, percent growth inhibition at one concentration: 66%
Compound 4: middle estimate off by 21 percentage points, on the low side, and the stated range ends below it.
By their numbers in this assay, from the lowest: compounds 2 and 3 (each within the scatter of the next); then compounds 4 and 1 (each within the scatter of the next).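

The aromatic carbon that carries thiophen-2-yl proves to be a position that responds: in this assay, 4-chlorobenzyl there gives a number 26 percentage points higher from compound 2 to compound 4 (beyond the scatter). Among the compounds shown here, the earlier step showed change only at the nitro and methoxy site, so this is the first sign that the other end of the molecule also moves growth inhibition. Nothing available bears on why the number rises.

From the compounds shown here alone, whether the rise follows the chlorine, the extra carbon link or the six-membered ring stays open; a plain benzyl or a phenyl on this carbon would separate these. Also open, going by these compounds, is whether the same swap would hold with methoxy in place of nitro.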